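Acetoxymethyl in place of acetyl on the shared core

A few compounds are considered here, and "the series" means these few. Any claim that something is new, unique, unknown or untested is made for them only; others in the source may bear on it.

Measured compounds:
Compound 1 `CC(=O)c1c(C)nc2c(OCc3ccccc3)cccn12`: 9%
Compound 2 `Cc1nc2c(OCc3ccccc3)cccn2c1CCC#N`: 20%
Compound 3 `COC(=O)Cc1c(C)nc2c(OCc3ccccc3)cccn12`: 16%

In a functional assay on the whole organism (stomach) for inhibition, with Canis familiaris (Canis lupus familiaris) as the target, at a dose of 5 mg/kg by the intravenous route (on this read-out higher numbers stand for a stronger effect at the one dose given and lower numbers for a weaker effect), compound 1 gives 9%, the lowest of the three numbers shown. Compound 3 gives 16%, which is a number 7 percentage points higher from compound 1 to compound 3 (within the scatter); compound 2 gives 20%, which is a number 11 percentage points higher from compound 1 to compound 2 (beyond the scatter). The unmeasured compound 4 `CC(=O)OCc1c(C)nc2c(OCc3ccccc3)cccn12` differs from compound 1 at the same aromatic carbon: acetoxymethyl in place of acetyl on an aromatic carbon.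

Among the compounds with values here, two measured steps bear on this change, both replacing the acetyl group on that carbon. The step of a number 11 percentage points higher from compound 1 to compound 2 (beyond the scatter) is modest but beyond the scatter, while the step of a number 7 percentage points higher from compound 1 to compound 3 (within the scatter) stays within it. Neither exchange resembles acetoxymethyl closely, so the guide is weak: at most a small rise is expected in this assay, possibly none beyond the scatter. Compound 4 is therefore estimated at 15%, with a range from 5% to 28%, meaning an expected step of a number 6 percentage points higher from compound 1 to compound 4 (within the scatter).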

Compound 4, a percentage reported as inhibition, in the whole organism at one dose (the size of the read-out at that dose, not a potency): 87%
For compound 4 the middle estimate is 72 percentage points below the measured one; the whole stated range lies below it.
By their numbers in this assay, from the lowest: compounds 1, 3 and 2 (each within the scatter of the next, the first and the last beyond it); then compound 4.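

Within the data shown here, at this aromatic carbon of the shared core, the choice of group matters far more than the earlier compounds suggested: in this assay, acetoxymethyl in place of acetyl gives a number 78 percentage points higher from compound 1 to compound 4 (beyond the scatter). Changing only what is attached to the saturated chain carbon also has a large effect, with acetoxy in place of methoxycarbonyl giving a number 71 percentage points higher from compound 3 to compound 4 (beyond the scatter) and acetoxy in place of cyanomethyl giving a number 67 percentage points higher from compound 2 to compound 4 (beyond the scatter). Compound 2 and compound 3 also carry a chain at this position, so among these compounds a chain alone does not give the high number seen with compound 4.

Nothing available here explains why the acetoxymethyl group has such a large effect. The compounds shown leave open whether a hydroxymethyl group, an aminomethyl group or a longer ester such as propanoyloxymethyl would give a similar result.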